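This account rests on a few compounds, and the source may have more. Where it says the series, first, only, none or still open, it means among the compounds named here.

Three members of a shared core have been measured in a functional assay on SiHa cells (Homo sapiens) for inhibition, read by sulforhodamine B assay; a lower number here means a stronger inhibitor of growth, a higher number a weaker inhibitor of growth. Compound 1 `FC(F)(F)c1ccc(-c2ccc(-c3ccc(-c4nc5ccccc5[nH]4)cc3)cc2)cc1` gives 100000 nM. Compound 2 `FC(F)(F)Oc1ccc(-c2ccc(-c3ccc(-c4nc5ccccc5[nH]4)cc3)cc2)cc1` gives 38400 nM, and compound 3 `Cc1ccc2[nH]c(-c3ccc(-c4ccc(-c5ccc(C(F)(F)F)cc5)cc4)cc3)nc2c1` gives 33200 nM. From compound 1 to compound 2 the change is trifluoromethoxy in place of trifluoromethyl on an aromatic carbon, and it produced a 2.6-fold lower number from compound 1 to compound 2 (0.42 log units; beyond the scatter). From compound 1 to compound 3 the change is methyl in place of hydrogen on an aromatic carbon, and it produced a 3.0-fold lower number from compound 1 to compound 3 (0.48 log units; beyond the scatter). The values of compound 2 and compound 3 lie within the scatter of each other, so no order between them is claimed.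

Compound 4 `Cc1ccc2[nH]c(-c3ccc(-c4ccc(-c5ccc(OC(F)(F)F)cc5)cc4)cc3)nc2c1` has not yet been measured in this assay. It differs from compound 3 by trifluoromethoxy in place of trifluoromethyl on an aromatic carbon. This is the same change that was made from compound 1 to compound 2, at a place described in the same words, while the two cores differ in the way described from compound 1 to compound 3. For the measured compounds named here, for compound 4 the step from compound 3 is expected to be a 2.6-fold lower number from compound 3 to compound 4 (0.41 log units; beyond the scatter), close in size to the earlier one, because a 2.6-fold lower number from compound 1 to compound 2 (0.42 log units; beyond the scatter) is the only measure of this change at hand, and the two changes so far each gave a modest step beyond the scatter from compound 1. Compound 4 is therefore estimated to give 13000 nM in this assay, with the range 6000 nM to 30000 nM allowing for the scatter of such measurements.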

Compound 4, concentration for 50% growth inhibition: 28300 nM
Compound 4: middle estimate off by 2.2-fold (0.34 log units), on the low side; the measured number falls inside the stated range.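

In this assay, trifluoromethoxy in place of trifluoromethyl on the core that carries the methyl gave a 1.2-fold lower number from compound 3 to compound 4 (0.07 log units; within the scatter), and methyl in place of hydrogen on the core that carries the trifluoromethoxy gave a 1.4-fold lower number from compound 2 to compound 4 (0.13 log units; within the scatter). The trifluoromethoxy change cannot be said to behave differently on the two cores, although the pair also does not establish that its size carries over, as the step was beyond the scatter on one core and within it on the other: the same change on two cores in this assay, a 2.6-fold lower number (0.42 log units; beyond the scatter) from compound 1 to compound 2 and a 1.2-fold lower number (0.07 log units; within the scatter) from compound 3 to compound 4, 2.2-fold (0.35 log units) apart, within the scatter of two such steps. The same reading applies to the methyl change, which offers a single comparison across two cores and so shows no clear dependence on the core, but also no firm additive rule: the same change on two cores in this assay, a 3.0-fold lower number (0.48 log units; beyond the scatter) from compound 1 to compound 3 and a 1.4-fold lower number (0.13 log units; within the scatter) from compound 2 to compound 4, 2.2-fold (0.35 log units) apart, within the scatter of two such steps.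

The compounds shown leave open how the series would respond to an amine, a carboxylic acid or a longer chain in place of the 4-(trifluoromethyl)phenyl or 4-(trifluoromethoxy)phenyl end, or to groups other than methyl on the core. They also leave open whether these small steps would look the same in a cell line other than SiHa, or on a core whose numbers are much lower than those seen here.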